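The compounds below may be only part of what the source reports. "The series", "measured", "known", "first", "only" and "open" are said of these compounds alone.

In a functional assay on brain (Rattus norvegicus, strain Wistar) for inhibition (on this read-out lower numbers stand for stronger inhibition and higher numbers for weaker inhibition), compound 1 `CCCCOc1ccc(-c2c(C)[nH]c(=O)n2C)cc1` gives 5100 nM, at the low end of the three numbers together with compound 3 `CCCCCc1ccc(-c2c(C)[nH]c(=O)n2C)cc1`, which gives 5900 nM. Compound 2 `CCCCOc1ccc(-c2c(C)[nH]c(=O)n2C2CCCCC2)cc1` stands higher at 13900 nM.

Compound 4 `CCCCCCCCCCCOc1ccc(-c2c(C)[nH]c(=O)n2C)cc1` differs from compound 1 by heptyl in place of hydrogen on a saturated chain carbon, four bonds along the chain from an oxygen on an aromatic ring. The closest measured evidence is a 1.2-fold higher number from compound 1 to compound 3 (0.06 log units; within the scatter), which replaces butoxy with pentyl at the same end of the molecule and stays within the scatter. The other measured step, a 2.7-fold higher number from compound 1 to compound 2 (0.44 log units; beyond the scatter), is modest but concerns the aromatic nitrogen, so it says little about this chain. Going by the values given here, no measured compound carries a chain this long, and the size of the change leaves the outcome open. A modest move towards a lower number in this assay is a tentative expectation, and a result with no change beyond the scatter would not be surprising. The expected step is a 1.7-fold lower number from compound 1 to compound 4 (0.23 log units; within the scatter). For compound 4 the estimated value is 3000 nM, with an expected range of 600 nM to 15000 nM.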

Compound 4, half-maximal inhibitory concentration: 9700 nM
For compound 4 the middle estimate is 3.2-fold (0.51 log units) below the measured one, and the stated range covers the measured number.
By their numbers in this assay, from the lowest: compounds 1, 3, 4 and 2 (each within the scatter of the next, the first and the last beyond it).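

At the saturated chain carbon four bonds along the chain from an oxygen on an aromatic ring, heptyl in place of hydrogen gives a 1.9-fold higher number from compound 1 to compound 4 (0.28 log units; within the scatter) in this assay, so this addition of 7 heavy atoms does not shift the number beyond the scatter. Going by these compounds alone, the earlier steps changed only the aromatic nitrogen substituent or swapped butoxy for pentyl, so this is the first reading of a much longer chain on the core of compound 1. Nothing shown gives a measured reason for this result.

A single step at this position gives no trend with chain length, and a propyl group in the same place could lie anywhere relative to it. As far as these compounds go, it also remains open whether an amine or a carboxylic acid in place of heptyl would keep the number within the scatter of compound 1.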